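Neopentyl to tert-Butyl on Two Cores and Clearance

A few compounds are considered here, and "the series" means these few. Any claim that something is new, unique, unknown or untested is made for them only; others in the source may bear on it.

Compound 1 `CC(C)(C)C[C@@H](O)C(=O)N1N=CC[C@H]1C(=O)NCc1cc(Cl)ccc1-n1cnnn1` was tested in an ADME assay on liver for metabolic stability, with Liver microsome (Homo sapiens) as the target, read by LC-MS, using microsomes (on this read-out higher numbers stand for fast clearance and lower numbers for slow clearance), and gave 22 mL.min-1.g-1. Compound 2 `CC(C)(C)[C@@H](O)C(=O)N1N=CC[C@H]1C(=O)NCc1cc(Cl)ccc1-n1cnnn1` shares the core of compound 1 but carries a shorter side chain. In this assay compound 2 reached only < 12 mL.min-1.g-1, which is a limit of the assay rather than a number (the limit of < 12 mL.min-1.g-1 in this assay, at which 1 of the 3 values shown sits). The change between the two is tert-butyl in place of neopentyl on a saturated chain carbon bound to a carbonyl carbon and an oxygen on a saturated carbon, and it produced an at least 1.8-fold lower number from compound 1 to compound 2 (0.26 log units; that floor lies within the scatter).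

Compound 3 `CC(C)(C)C[C@@H](O)C(=O)N1[C@@H]2C[C@@H]2C[C@H]1C(=O)NCc1cc(Cl)ccc1-n1cnnn1` is built on a different core; the difference between the two cores is not broken down here. In this assay compound 3 gives 71 mL.min-1.g-1, the highest of the numbers measured and beyond the scatter from compound 1.

Compound 4 `CC(C)(C)[C@@H](O)C(=O)N1[C@@H]2C[C@@H]2C[C@H]1C(=O)NCc1cc(Cl)ccc1-n1cnnn1` has not yet been measured. It differs from compound 3 by tert-butyl in place of neopentyl on a saturated chain carbon bound to a carbonyl carbon and an oxygen on a saturated carbon, the same change that separates compound 1 from compound 2. Because that change gave an at least 1.8-fold lower number from compound 1 to compound 2 (0.26 log units; that floor lies within the scatter) on the core of compound 1, a step of at least similar size is expected on the core of compound 3, with the caution that the earlier step rests on a limit and only shows a floor. The expected step in this assay is a 2.2-fold lower number from compound 3 to compound 4 (0.35 log units; beyond the scatter). Compound 4 is therefore estimated to give 32 mL.min-1.g-1 in this assay, with a likely range from 14 mL.min-1.g-1 to 60 mL.min-1.g-1.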

Compound 4, intrinsic clearance in microsomes: 54 mL.min-1.g-1
Compound 4: middle estimate off by 1.7-fold (0.23 log units), on the low side; the range from low to high includes it.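

In this assay, the exchange of neopentyl for tert-butyl on the core of compound 3 comes to a 1.3-fold lower number from compound 3 to compound 4 (0.12 log units; within the scatter), so on this core the change does not stand out from the repeat variation of the read-out. Neither step between the two pairs is shown to lie beyond the scatter, and the data do not show whether the change carries from one core to the other with the same size: the same change on two cores in this assay, an at least 1.8-fold lower number (0.26 log units; that floor lies within the scatter) from compound 1 to compound 2 and a 1.3-fold lower number (0.12 log units; within the scatter) from compound 3 to compound 4; the limit leaves it open whether they differ. Compound 2 stands at a limit of the assay and not at a number, and therefore the step on the core of compound 1 gives only a floor, with no upper bound on its size: the limit of < 12 mL.min-1.g-1 in this assay, at which 1 of the 4 values shown sits.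

The compounds shown hold only neopentyl and tert-butyl at this place on just two cores, and they leave open how a longer chain, a cyclohexyl ring or a carboxylic acid on the same saturated chain carbon would read in this assay. They also leave open whether the same exchange would give a step beyond the scatter on any further core, since two pairs cannot establish a trend across the series.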